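One Methoxy Fewer on the Ring Beside the Carbonyl

The source may report more compounds than this note shows. Statements on the series, on what has been measured and on what is new or still open speak of the compounds shown alone.

Measured compounds and their values:
compound 1, `COc1cc(-c2cc(/C=C/C(=O)c3ccc(N)cc3)[nH]n2)cc(OC)c1OC`, 94%
compound 2, `COc1cc(-c2cc(/C=C/C(=O)c3ccc(Cl)c(Cl)c3)[nH]n2)cc(OC)c1OC`, 94%
compound 3, `COc1ccc(C(=O)/C=C/c2cc(-c3cc(OC)c(OC)c(OC)c3)n[nH]2)cc1OC`, 94%

The three measured compounds share a core and differ only in the aryl group attached to the carbonyl carbon. In a functional assay on 786-0 cells (Homo sapiens) for cytotoxicity, read by sulforhodamine B assay, with a stated time of 48 h, tested at 0.1 uM (on this read-out lower numbers stand for a stronger effect and higher numbers for a weaker effect at the one concentration tested), compound 3 gives 94%, and on the numbers shown it stands level with compound 1 and compound 2: every measured value lies at the high end of the scale, where the cells are barely affected at the single concentration tested.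

The measured steps all concern that aryl group. no change at the digits printed from compound 1 to compound 2 (within the scatter), no change at the digits printed from compound 1 to compound 3 (within the scatter) and no change at the digits printed from compound 2 to compound 3 (within the scatter): none of these exchanges moved this assay beyond its scatter, whether the group was 4-aminophenyl, 3,4-dichlorophenyl or 3,4-dimethoxyphenyl.

Compound 4, `COc1ccc(C(=O)/C=C/c2cc(-c3cc(OC)c(OC)c(OC)c3)n[nH]2)cc1`, differs from compound 3 in the same region: hydrogen in place of methoxy on an aromatic carbon. Since three different aryl groups on the carbonyl carbon gave the same reading, a further trimming of one methoxy is expected to leave this assay unchanged, so no change at the digits printed from compound 3 to compound 4 (within the scatter) is expected to be no step beyond the scatter. Compound 4 is therefore estimated at 94%, within a range from 82% to 104%.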

Compound 4, a percentage reported as activity, at one concentration (the size of the read-out at that concentration, not a potency): 96%
Beside the measured number, compound 4's estimate is 2 percentage points below it; measured number inside the range.
By their numbers in this assay, from the lowest: compounds 1, 2, 3 and 4 (each within the scatter of the next).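

Trimming the 3,4-dimethoxyphenyl group to 4-methoxyphenyl gives, in this assay, a number 2 percentage points higher from compound 3 to compound 4 (within the scatter). Unlike the earlier exchanges, which replaced one aryl group with another, this step removes a single methoxy and leaves the rest of the group in place, so this one methoxy makes no visible difference to the reading at the one concentration tested. The 4-methoxyphenyl group also matches the two other aryl groups, with a number 2 percentage points higher from compound 2 to compound 4 (within the scatter) and a number 2 percentage points higher from compound 1 to compound 4 (within the scatter), so four groups on the carbonyl carbon now give readings that cannot be told apart, and nothing available explains this flat result.

All four readings lie at the end of the scale where the cells are barely affected, so this single concentration cannot show whether the methoxy would matter at a higher concentration, where an effect might be large enough to compare. From the compounds shown here alone, it also remains open whether removing the last methoxy to leave plain phenyl, or placing a hydroxyl group or a carboxylic acid on the same ring, would shift the reading beyond the usual scatter.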